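A few compounds are considered here, and "the series" means these few. Any claim that something is new, unique, unknown or untested is made for them only; others in the source may bear on it.

Values in a physicochemical assay for acid dissociation:
- compound 1 `COc1ccc(F)cc1CNCCCNc1ccnc2cc(Oc3ccc(F)cc3)ccc12`: 9.28
- compound 2 `COc1cccc(CNCCCNc2ccnc3cc(-c4ccc(C(C)(C)C)cc4)ccc23)c1O`: 9.47
- compound 3 `CC(C)(C)c1ccc(-c2ccc3c(NCCCNCc4ccco4)ccnc3c2)cc1`: 9.47

Compound 2, at 9.47, is level with compound 3, and compound 1, at 9.28, lies within the scatter of both. The three values therefore show no separation in this assay.

The next compound is compound 4 `COc1cccc(CNCCCNc2ccnc3cc(Cc4cccc(C(F)(F)F)c4)ccc23)c1O`, which is still to be measured. The change is 3-(trifluoromethyl)benzyl in place of 4-(tert-butyl)phenyl on an aromatic carbon. It sits on an aromatic carbon, meta to a fused ring and para to a fused ring.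

Among the compounds with values here, only one measured step is available, no change at the digits printed from compound 2 to compound 3 (within the scatter). That step replaces 2-hydroxy-3-methoxyphenyl on a saturated chain carbon bound to an amine nitrogen, so it bears only indirectly on a change made on an aromatic carbon. Within the data shown here, no measured step isolates a change at the aromatic carbon itself. Compound 1 differs from compound 2 in more than one place, so compound 1, at 9.28, gives only the general level of the set.

With nothing in these data pointing to a shift, no change beyond the scatter is expected in this assay. The estimated step is a number 0.07 log units lower from compound 2 to compound 4 (within the scatter). For compound 4 the expected value is 9.4, with an estimated range from 9.1 to 9.7.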

Compound 4, acid dissociation constant: 9.47
Compound 4: middle estimate off by 0.07 log units, on the low side; the range from low to high includes it.
By their numbers in this assay, from the lowest: compounds 1, 2, 3 and 4 (each within the scatter of the next).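

In this assay, 3-(trifluoromethyl)benzyl in place of 4-(tert-butyl)phenyl on the aromatic carbon para to a fused ring gives no change at the digits printed from compound 2 to compound 4 (within the scatter). Within the data shown here, this is the first single-place reading at this aromatic carbon, and it extends the picture from the earlier step on a saturated chain carbon bound to an amine nitrogen, which gave no change at the digits printed from compound 2 to compound 3 (within the scatter); for these two changes, a replacement at either place leaves the read-out without a step beyond the scatter. Nothing in the available data accounts for this result.

The step exchanges the ring substituent and the attachment together, so the compounds shown cannot separate the effect of the trifluoromethyl group from that of the benzyl attachment, and a 3-(trifluoromethyl)phenyl group at this carbon would be the direct link between compound 2 and compound 4. Also open, going by these compounds, is whether the read-out would hold with a group of another kind at this aromatic carbon, such as an amine or a carboxylic acid, or with a longer chain in place of the one carrying the amine nitrogen.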